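Compound 3 to compound 4: the chain change

The compounds below may be only part of what the source reports. "The series", "measured", "known", "first", "only" and "open" are said of these compounds alone.

Values in a physicochemical assay for solubility, in phosphate buffer, measured as kinetic solubility, at pH 7.4, tested at 250 uM (a lower number here means a less soluble compound, a higher number a more soluble compound), are as follows.
- compound 1 `CCCCNc1ccc([N+](=O)[O-])cc1S(N)(=O)=O` gives 85000 nM
- compound 2 `CCCCCCNc1ccc([N+](=O)[O-])cc1S(N)(=O)=O` gives 6000 nM
- compound 3 `CN(C)S(=O)(=O)c1cc(C(=O)O)ccc1NCCC(C)(C)C` gives > 250000 nM as a limit, not a number

Compound 3 therefore has no exact position in this assay and stands only at that limit. Next comes compound 4 `COCCCCCCNc1ccc(C(=O)O)cc1S(=O)(=O)N(C)C` with this change: 4-methoxybutyl in place of tert-butyl on a saturated chain carbon, two bonds along the chain from a nitrogen on an aromatic ring. Among the compounds with values here, one measured step bears on it, a 14-fold lower number from compound 1 to compound 2 (1.15 log units; beyond the scatter), which is large and lies on the core of compound 1, not that of compound 3. On the strength of that step, a lower number is expected for compound 4, though by a smaller margin, and a result at the limit remains possible. The expected step runs an at least 1.4-fold lower number from compound 3 to compound 4 (0.16 log units; that floor lies within the scatter). For compound 4 the estimate is 170000 nM, with an expected range from 80000 nM to 250000 nM.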

Compound 4, solubility: > 250000 nM
Compound 4: no number, only a limit; the forecaster's own chance of this, stated with the estimate: 45%; at least 1.4-fold (0.16 log units) between middle value and limit.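

No step from compound 3 to compound 4 can be read, because both stand only as limits: the limit of > 250000 nM in this assay, at which 2 of the 4 values shown sit.

The compounds shown leave open what 4-methoxybutyl in place of tert-butyl does to the solubility read-out on their shared core.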